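The source may hold more compounds than are shown below. What is called first, only, known or untested is meant among the compounds shown, and "the series" means these compounds.

Compound 1 `O=C(Nc1ccc2nc(NC(=O)C3CCCCC3)sc2c1)c1c(Cl)cccc1Cl` gives 0.015 ug/mL in a functional assay on WI-38 VA13 cells (Homo sapiens) for cytotoxicity; a higher number here means that more compound is needed for the effect, a lower number that less compound is needed.
Compound 2 `Cc1[nH][n+](C)c(C)c1C(=O)Nc1ccc2nc(NC(=O)C3CCCCC3)sc2c1` gives 0.012 ug/mL in this assay.

On these two numbers compound 1 gives the higher one, yet the step of a 1.3-fold lower number from compound 1 to compound 2 (0.10 log units; within the scatter) lies within the scatter, so the two compounds cannot be told apart. Compound 3 `CCCOC(=O)Nc1nc2ccc(NC(=O)c3c(Cl)cccc3Cl)cc2s1` has not yet been measured. It differs from compound 1 in one place: propoxy in place of cyclohexyl on a carbonyl carbon. Within the data shown here, the only measured step, a 1.3-fold lower number from compound 1 to compound 2 (0.10 log units; within the scatter), concerns the other carbonyl of the shared core, so it does not bear on this exchange, and no measured pair shows how this place responds. The expectation for compound 3 therefore rests on compound 1 alone and is given a wide range. The expected step is a 1.3-fold higher number from compound 1 to compound 3 (0.12 log units; within the scatter), with no change beyond the scatter anticipated. Compound 3 is estimated at 0.02 ug/mL, with a range from 0.005 ug/mL to 0.08 ug/mL.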

Compound 3, half-maximal effective concentration: 0.0025 ug/mL
Estimate against measurement, compound 3: 8.0-fold (0.90 log units) above; the measured number lies below the stated range.
By their numbers in this assay, from the lowest: compound 3; then compounds 2 and 1 (each within the scatter of the next).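

The exchange of cyclohexyl for propoxy on this carbonyl carbon gives a 6.0-fold lower number from compound 1 to compound 3 (0.78 log units; beyond the scatter) in this assay, so less compound is needed for the effect. The only earlier step, a 1.3-fold lower number from compound 1 to compound 2 (0.10 log units; within the scatter), concerned the other carbonyl of the shared core, so this is the first sign that the number can move clearly with a change in the compounds shown, here at the group on the carbonyl carbon that also carries the amide-type nitrogen. Nothing available explains why this exchange lowers the number.

The exchange removes a ring and brings in an oxygen at the same time, so the compounds shown cannot separate these two changes; a plain propyl group or a cyclohexyloxy group at this place would pull them apart. From the compounds shown here alone, whether propoxy would act the same way alongside the five-membered ring of compound 2 also remains open.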